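The source may hold more compounds than are shown below. What is called first, only, known or untested is meant among the compounds shown, and "the series" means these compounds.

Working notes on the series. Of the compounds shown here, two have been measured so far in a functional assay on HeLa cells (Homo sapiens) for cytotoxicity, read by MTT assay, with a stated time of 48 h, tested at 100 uM; a higher number here means a stronger effect of the compound at the concentration tested, a lower number a weaker effect. Compound 1, `CS(=O)(=O)c1ccc(Cc2n[nH]c(=S)n2/N=C/c2c(F)cccc2Cl)cc1`, gives 77.3% in this assay. Compound 2, `CS(=O)(=O)c1ccc(Cc2n[nH]c(=S)n2/N=C/c2ccc(-c3ccccc3)cc2)cc1`, gives 69.5% in this assay; of the two numbers this is the lower, but the gap to compound 1 lies within the scatter, so the two stand level for practical purposes and no order between them can be read from the data.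

Compound 3, `CSc1ccc(/C=N/n2c(Cc3ccc(S(C)(=O)=O)cc3)n[nH]c2=S)cc1`, is the next to be measured. It differs from compound 2 in one place: methylsulfanyl in place of phenyl on an aromatic carbon. No step between measured compounds is available that would show what such a change does in this assay, so the expectation can rest only on the two numbers shown, which sit close together.

For compound 3 a step of a number 1.5 percentage points lower from compound 2 to compound 3 (within the scatter) from compound 2 is expected, that is, nothing beyond the scatter in either direction. Compound 3 is therefore estimated at 68% in this assay, with a range from 50% to 84%.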

Compound 3, a percentage reported as activity, at one concentration (the size of the read-out at that concentration, not a potency): 71.9%
For compound 3 the middle estimate is 3.9 percentage points below the measured one; the measured number falls inside the stated range.
By their numbers in this assay, from the lowest: compounds 2, 3 and 1 (each within the scatter of the next).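

In this assay the exchange of phenyl for methylsulfanyl on an aromatic carbon, para to a large group, gives a number 2.4 percentage points higher from compound 2 to compound 3 (within the scatter) and so provides the first step read at this place: the entering group has 2 heavy atoms against 6 and no ring, yet the change stays within the scatter. The comparison with 4-(methylsulfanyl)phenyl in place of 2-chloro-6-fluorophenyl on a carbon with a double bond to nitrogen gives a number 5.4 percentage points lower from compound 1 to compound 3 (within the scatter) and likewise stays within the scatter, so compound 1, compound 2 and compound 3 stand level in this read-out despite their different aromatic groups. Nothing available explains these numbers.

As far as these compounds go, it remains open whether any group at the aromatic carbon can move the number beyond the scatter, for example an amine, a carboxylic acid or a longer alkyl chain on the sulfur in place of methyl. With one concentration per compound, these numbers also leave open how potency compares among compound 1, compound 2 and compound 3.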